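A few compounds are considered here, and "the series" means these few. Any claim that something is new, unique, unknown or untested is made for them only; others in the source may bear on it.

Measured so far:
- compound 1 `Cc1ccccc1-c1cc(C#Cc2ccc(CCC(=O)O)cc2)ccn1`: 92%
- compound 2 `O=C(O)CCc1ccc(C#Cc2ccnc3cc(Cl)ccc23)cc1`: 125%

In an in vitro functional assay on 1321-N1 cells for agonist activity at Free fatty acid receptor 1 (Homo sapiens), read by fluorescence, spectrophotometry and calcium flux (on this read-out higher numbers stand for larger maximal responses and lower numbers for smaller maximal responses), compound 1 holds the lower of the two numbers; compound 2 stands a good way higher, beyond the scatter. Compound 3 `O=C(O)CCc1ccc(C#Cc2ccnc(Cl)c2)cc1` remains to be measured. Relative to compound 1 it carries chloro in place of 2-methylphenyl on an aromatic carbon. Going by the values given here, no measured pair shows this exact change, so the direction is uncertain; the chloro in compound 2 gives no direct reading for it. A step from compound 1 to compound 3 of a number 8 percentage points higher from compound 1 to compound 3 (within the scatter) in this assay is expected, upward but not clearly beyond the scatter. For compound 3 the expected maximal response is 100%, within 70% to 130%.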

Compound 3, largest response reached (reported as efficacy), in percent of the reference or control that the assay uses: 94%
Beside the measured number, compound 3's estimate is 6 percentage points above it; measured number inside the range.
By their numbers in this assay, from the lowest: compounds 1 and 3 (each within the scatter of the next); then compound 2.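

In this assay, the step of a number 2 percentage points higher from compound 1 to compound 3 (within the scatter) comes with chloro in place of 2-methylphenyl on an aromatic carbon next to the ring nitrogen. At this position, then, the whole 2-methylphenyl group, with its six-membered aromatic ring, can give way to a single chlorine without a step beyond the scatter, so the maximal response does not rest on that ring being present. On these data alone, whether an amine or a methoxy group at the same carbon would also leave the maximal response within the scatter stays open. No measurement among these compounds offers an explanation for the flat step.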